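A few compounds are considered here, and "the series" means these few. Any claim that something is new, unique, unknown or untested is made for them only; others in the source may bear on it.

Measured so far:

Compound 1: `COC1CN(C(=O)/C=C/c2ccncc2-c2ccc3[nH]ncc3c2)C1` — 98%
Compound 2: `O=C(O)CCc1ccncc1-c1ccc2ccccc2c1` — 101%

Both measured compounds were tested in an assay on a protein complex for inhibition of CDK8/Cyclin C (Homo sapiens), with a stated time of 1 h, tested at 10 uM; on this read-out lower numbers stand for less inhibition and higher numbers for more inhibition at the one concentration tested (going by the name of the read-out). Compound 1 gives 98% in this assay, and compound 2 gives 101%. Compound 2 carries the higher of the two numbers, but the gap to compound 1 is within the scatter, so the two read as equal; both numbers sit near the top of the read-out at the single concentration tested.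

The next compound, compound 3, is `CNC(=O)COc1ccncc1-c1ccc2ccccc2c1`. It differs from compound 2 in one place: (methylcarbamoyl)methoxy in place of 2-carboxyethyl on an aromatic carbon. For the measured compounds named here, no step between measured compounds exists in this set, so the size of the expected change rests on the single high reading of compound 2 alone. Since compound 2 gives 101% in this assay, a reading of that size leaves no room for an increase; the open question is only whether the exchange lowers the number. A modest fall, somewhat beyond the scatter, is the expectation, and the estimated step of a number 19 percentage points lower from compound 2 to compound 3 (beyond the scatter) reflects that. Compound 3 is expected to give 82% in this assay, with a range from 50% to 100%.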

Compound 3, a percentage reported as inhibition, at one concentration (the size of the read-out at that concentration, not a potency): 4%
Estimate against measurement, compound 3: 78 percentage points above; measured number outside the range, below it.
By their numbers in this assay, from the lowest: compound 3; then compounds 1 and 2 (each within the scatter of the next).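

In this assay, (methylcarbamoyl)methoxy in place of 2-carboxyethyl, on the aromatic carbon opposite the ring nitrogen and ortho to a large group, gives a number 97 percentage points lower from compound 2 to compound 3 (beyond the scatter), which shows that the read-out at this single concentration depends strongly on the group at this position. The counted difference between the two groups is small: 6 heavy atoms against 5, with a nitrogen entering, 2 hydrogen-bond acceptors against 1, and the same count of donors, with no ring and no net charge on either side, so a modest change in these counts can accompany a large step. No measurement available here bears on why the step is this large.

Still open, as far as these compounds go, is whether the step follows the amide, the oxygen attached to the ring, or both, a question that a 2-(methylcarbamoyl)ethyl group or a carboxymethoxy group at this position would separate. From the compounds shown here alone, compound 1 differs from compound 2 and compound 3 in more than one place, so steps to it cannot be read, and whether the same exchange has a similar effect on its core also remains open.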